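This account rests on a few compounds, and the source may have more. Where it says the series, first, only, none or still open, it means among the compounds named here.

Compound 1 `O=C(Nc1cccc(-n2cc(-c3ccncc3)c(-c3ccc(Cl)c(O)c3)n2)c1)Nc1cccc(C(F)(F)F)c1`: 1300 nM
Compound 2 `COc1cc(-c2nn(-c3cccc(NC(=O)c4cccc(C(F)(F)F)c4)c3)cc2-c2ccncc2)ccc1Cl`: 978 nM
Compound 3 `COc1cc(-c2nn(-c3cccc(NC(=O)Nc4ccc(Cl)c(Cl)c4)c3)cc2-c2ccncc2)ccc1Cl`: 741 nM

All three were measured in a functional assay on SK-MEL-5 cells (Homo sapiens) for inhibition, read by sulforhodamine B assay, with a stated time of 48 h; on this read-out higher numbers stand for weaker inhibition of growth and lower numbers for stronger inhibition of growth. Compound 3 gives the lowest of the three numbers, yet both others sit close to it: the move from compound 2 to compound 3, a 1.3-fold lower number from compound 2 to compound 3 (0.12 log units; within the scatter), stays within the scatter, and the gap to compound 1 does too. Compound 4 `O=C(Nc1cccc(-n2cc(-c3ccncc3)c(-c3ccc(Cl)c(O)c3)n2)c1)Nc1ccc(Cl)c(Cl)c1` carries the change (hydrogen in place of methyl on an oxygen on an aromatic ring). Going by the values given here, no measured step covers this change alone. Compound 1 also bears a hydroxy group, but it differs from compound 3 at the urea as well, and compound 1 gives 1300 nM, which only shows that both forms sit in the same band. In this assay compound 4 is therefore expected to stay in that band, with a step of a 1.3-fold higher number from compound 3 to compound 4 (0.13 log units; within the scatter), estimated at 1000 nM within 450 nM to 2300 nM.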

Compound 4, concentration for 50% growth inhibition: 570 nM
Compound 4: middle estimate off by 1.8-fold (0.24 log units), on the high side, and the stated range covers the measured number.
By their numbers in this assay, from the lowest: compounds 4, 3, 2 and 1 (each within the scatter of the next, the first and the last beyond it).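

In this assay, going by these compounds alone, a 1.3-fold lower number from compound 3 to compound 4 (0.11 log units; within the scatter) is the first reading of this change alone, and it lies within the scatter, so 4-chloro-3-methoxyphenyl and 4-chloro-3-hydroxyphenyl cannot be told apart here. With the hydroxy group in place, a 2.3-fold lower number from compound 1 to compound 4 (0.36 log units; beyond the scatter) is a modest step beyond the scatter, with 3,4-dichlorophenyl in place of 3-(trifluoromethyl)phenyl on an amide-type nitrogen. No evidence is available that accounts for either step. Open, as far as these compounds go, is whether ethoxy, or an amine in place of the hydroxy group, would stay in this band, and whether the 3,4-dichlorophenyl step recurs with methoxy present.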